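Compound 3: cyano in place of hydrogen on the chain

The source may hold more compounds than are shown below. What is called first, only, known or untested is meant among the compounds shown, and "the series" means these compounds.

Compound 1 `Cc1nc(C(C)(C)C)nc2nc(N)c(C#N)c(N)c12` – 37000 nM
Compound 2 `CCCCc1nc(C(C)(C)C)nc2nc(N)c(C#N)c(N)c12` – 6000 nM

Going by the values given here, in a physicochemical assay for solubility, in phosphate buffer, with a stated time of 18 h (a lower number here means a less soluble compound, a higher number a more soluble compound), compound 2 stands at 6000 nM and holds the lower of the two numbers so far. Compound 3 `CC(C)(C)c1nc(CCCCC#N)c2c(N)c(C#N)c(N)nc2n1` has not yet been measured. Against compound 2 the change is cyano in place of hydrogen on a saturated chain carbon, four bonds along the chain from an aromatic carbon and the same difference, cut one bond further out, reads propyl to 3-cyanopropyl.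

Among the compounds with values here, only one measured step bears on this change. It is a 6.2-fold lower number from compound 1 to compound 2 (0.79 log units; beyond the scatter) and it came with propyl in place of hydrogen on a saturated chain carbon bound to an aromatic carbon. Within the data shown here, that modest step alters a chain as well, but it brings in no cyano, and no measured pair shows what a cyano does here. The direction is therefore uncertain, and the measured step offers only a rough guide to size. A small move toward a higher number is expected, well short of the measured step. The step expected is a 2.2-fold higher number from compound 2 to compound 3 (0.34 log units; beyond the scatter) as an estimate. In this assay the estimate for compound 3 is 13000 nM with an expected range of 4500 nM to 36000 nM overall.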

Compound 3, solubility: 16000 nM
The estimate for compound 3 lay 1.2-fold (0.09 log units) below the measured number; the range from low to high includes it.
By their numbers in this assay, from the lowest: compound 2; then compound 3; then compound 1.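

Placed on a saturated chain carbon, four bonds along the chain from an aromatic carbon, the cyano shows that the far end of the chain still affects the reading in this assay, with a 2.7-fold higher number from compound 2 to compound 3 (0.43 log units; beyond the scatter), a step beyond the usual scatter. The earlier compounds shown here showed only that adding propyl lowered the number, whereas this change reverses part of that drop without shortening the chain. The recovery is incomplete, since replacing hydrogen with 3-cyanopropyl still leaves a 2.3-fold lower number from compound 1 to compound 3 (0.36 log units; beyond the scatter), so compound 3 sits between the other two, and nothing available explains why the cyano moves the number in this way.

The compounds shown leave open whether the same change would give a step of similar size and direction on a shorter chain, as in cyanomethyl or 2-cyanoethyl, or on a longer chain. They also leave open whether the higher number is particular to the nitrile, or whether an amine or a carboxylic acid at the same chain position would give a comparable reading.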